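The compounds below may be only part of what the source reports. "The series", "measured", "known", "first", "only" and "open" are said of these compounds alone.

Measured so far:
compound 1 `COc1c(F)c(F)cc2c(=O)c(C(=O)O)cn(Cc3ccc(-c4ccccc4)cc3)c12`: "not active" (no number reported)
compound 2 `COc1c(N2CC[C@@H](C(N)=O)C2)c(F)cc2c(=O)c(C(=O)O)cn(Cc3ccc(-c4ccccc4)cc3)c12`: 10%

In an assay on isolated protein for inhibition of DNA topoisomerase 1 (Homo sapiens), with a stated time of 15 min, tested at 200 uM (on this read-out lower numbers stand for less inhibition and higher numbers for more inhibition at the one concentration tested (going by the name of the read-out)), compound 1 came back as "not active" (no number reported), with no number given. In this assay, among the measured compounds shown here, compound 2 gives 10%, the only number recorded, so it has no neighbour to rank against. Compound 3 `COc1c(NCCN)c(F)cc2c(=O)c(C(=O)O)cn(Cc3ccc(-c4ccccc4)cc3)c12` is not yet measured; it differs from compound 2 by (2-aminoethyl)amino in place of 3-carbamoylpyrrolidin-1-yl on an aromatic carbon. For the measured compounds named here, with no measured step to lean on and compound 2 giving only a low number, the expected step of no change at the digits printed from compound 2 to compound 3 (within the scatter) is none beyond the usual scatter. Compound 3 is therefore estimated at 10%, within 0% to 25%.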

Compound 3, a percentage reported as inhibition, at one concentration (the size of the read-out at that concentration, not a potency): 10%
Compound 3: middle estimate and measured number agree at the digits printed; low and high end bracket the measured number.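

In this assay, putting the open-chain (2-aminoethyl)amino group in place of 3-carbamoylpyrrolidin-1-yl on this aromatic carbon gives no change at the digits printed from compound 2 to compound 3 (within the scatter). At this position, the read-out therefore does not separate a larger ring-bearing group with a defined stereocentre from a smaller chain without a ring. Nothing measured here offers an explanation for this result. Still open, from the compounds shown here alone, is whether a longer chain ending in an amine, or a piperazine ring, on this carbon would shift the read-out beyond the usual scatter.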